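The compounds below may be only part of what the source reports. "The series", "measured", "known", "first", "only" and "open" are said of these compounds alone.

Compound 1 `CN(C(=O)c1ccncc1)c1ccc(OCc2ccc3ccccc3n2)cc1` — 15 mL/min/kg
Compound 2 `CN(C(=O)c1cc(-c2ccccn2)[nH]n1)c1ccc(OCc2ccc3ccccc3c2)cc1` — 30 mL/min/kg
Compound 3 `CN(C(=O)c1ccncc1)c1ccc(OCc2ccc3ccccc3c2)cc1` — 75 mL/min/kg

In an ADME assay (liver) for metabolic stability, with Liver microsome (Rattus norvegicus) as the target, using microsomes (on this read-out lower numbers stand for slow clearance and higher numbers for fast clearance), compound 1 gives 15 mL/min/kg, the smallest number of the three, with compound 2 at 30 mL/min/kg so close that the two cannot be told apart, while compound 3 at 75 mL/min/kg sits clearly higher. Compound 4 `CN(C(=O)c1csc(-c2cccnc2)n1)c1ccc(OCc2ccc3ccccc3n2)cc1` is reached from compound 1 by one change: 2-(pyridin-3-yl)-1,3-thiazol-4-yl in place of pyridin-4-yl on a carbonyl carbon. Within the data shown here, the one comparable step runs the other way, from a two-ring group to the single pyridine: a 2.5-fold higher number from compound 2 to compound 3 (0.40 log units; beyond the scatter). Read in reverse, exchanging a pyridin-4-yl for a larger two-ring heteroaryl on the carbonyl carbon went with a modest drop in clearance. Compound 4 is therefore expected to move in that direction, though compound 1 already sits low, so the step is expected to be a 1.5-fold lower number from compound 1 to compound 4 (0.18 log units; within the scatter), modest at most and possibly inside the scatter. The clearance of compound 4 in this assay is estimated at 10 mL/min/kg, with a range from 4 mL/min/kg to 25 mL/min/kg.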

Compound 4, clearance: > 283 mL/min/kg
Compound 4: no number, only a limit; the forecaster's own chance of this, stated with the estimate: 5%; middle value at least 28-fold (1.45 log units) from the limit.
By their numbers in this assay, from the lowest: compounds 1 and 2 (each within the scatter of the next); then compound 3. At a limit, above all of these: compound 4.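

In this assay, the place on the carbonyl carbon bonded to the amide-type nitrogen proves highly sensitive to this exchange: 2-(pyridin-3-yl)-1,3-thiazol-4-yl in place of pyridin-4-yl gives an at least 18-fold higher number from compound 1 to compound 4 (1.27 log units; beyond the scatter). Compound 4 has no exact number here, only a limit: the limit of > 283 mL/min/kg in this assay, at which 1 of the 4 values shown sits. The earlier step, a 2.5-fold higher number from compound 2 to compound 3 (0.40 log units; beyond the scatter), had pyridin-4-yl on the higher side, so across these two pairs a larger two-ring group on this carbon does not move the clearance in a single direction.

The compounds shown leave open whether the rise belongs to the 1,3-thiazol-4-yl or to the pyridin-3-yl attached to it. A 1,3-thiazol-4-yl carrying a methyl group or an amine in place of the pyridine would separate the two.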